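Changing the acyl group on a thiophene carboxamide series

A few compounds are considered here, and "the series" means these few. Any claim that something is new, unique, unknown or untested is made for them only; others in the source may bear on it.

Compound 1 `N#Cc1ccccc1CN1CCc2c(sc(NC(=O)c3ccccc3Cl)c2C(N)=O)C1`: in a functional assay on HeLa cells (Homo sapiens) for antiproliferative activity, with a stated time of 24 h (on this read-out higher numbers stand for weaker inhibition and lower numbers for stronger inhibition), compound 1 sits at a limit of the assay, > 50000 nM (the limit of > 50000 nM in this assay, at which 1 of the 3 values shown sits).
Compound 2 `NC(=O)c1c(NC(=O)c2ccccc2Cl)sc2c1CCN(Cc1c(Cl)cccc1Cl)C2`: compound 2 gives 28800 nM.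
Compound 3 `NC(=O)c1c(NC(=O)c2ccccc2Cl)sc2c1CCN(Cc1ccc(Cl)cc1Cl)C2`: compound 3 gives 21100 nM.

Compound 2 stands at the upper of the two numbers shown, with compound 3 close by a 1.4-fold lower number from compound 2 to compound 3 (0.14 log units; within the scatter); the other value is only a limit. The steps of an at least 1.7-fold lower number from compound 1 to compound 2 (0.23 log units; that floor lies within the scatter) and an at least 2.3-fold lower number from compound 1 to compound 3 (0.37 log units; beyond the scatter) concern the group on the saturated chain carbon bound to the ring amine. Compound 4 `NC(=O)c1c(NC(=O)c2cccc([N+](=O)[O-])c2)sc2c1CCN(Cc1c(Cl)cccc1Cl)C2` instead changes the acyl side: 3-nitrophenyl in place of 2-chlorophenyl on a carbonyl carbon. Going by the values given here, no measured step touches this position, so no shift beyond the scatter is expected from compound 2 to compound 4 a 1.0-fold higher number from compound 2 to compound 4 (0.02 log units; within the scatter). Compound 4 is therefore estimated at 30000 nM, within 10000 nM to 90000 nM.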

Compound 4, half-maximal inhibitory concentration: 46100 nM
The estimate for compound 4 lay 1.5-fold (0.19 log units) below the measured number, within the range that was stated.
By their numbers in this assay, from the lowest: compounds 3, 2 and 4 (each within the scatter of the next, the first and the last beyond it). At a limit, above all of these: compound 1.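

Going by these compounds alone, compounds 1, 2 and 3 all carry 2-chlorophenyl on the carbonyl carbon, so the only reading of the acyl side in this assay is the exchange for 3-nitrophenyl, a 1.6-fold higher number from compound 2 to compound 4 (0.20 log units; within the scatter). This single pair shows that the exchange leaves compound 4 within the scatter of its parent, with the 2,6-dichlorophenyl group kept. Compound 1 remains the only one at a limit: the limit of > 50000 nM in this assay, at which 1 of the 4 values shown sits.

On these data alone, whether an acyl group carrying an amine, a carboxylic acid or a longer chain would shift the number stays open. So does whether 3-nitrophenyl behaves alike with the 2,4-dichlorophenyl group of compound 3.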